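The source may hold more compounds than are shown below. What is called first, only, known or untested is meant among the compounds shown, and "the series" means these compounds.

Compound 2 `C=C1C(=O)O[C@H]2C/C(C)=C/CC/C(C)=C/CC[C@@](C)(O)[C@@H](OC(C)=O)C[C@H]12` is the starting point of this small set. In a functional assay on A549 cells (Homo sapiens) for cytotoxicity, read by colorimetric assay and MTT assay (a lower number here means a stronger inhibitor, a higher number a weaker inhibitor), compound 2 gives > 30 ug/mL, which is a limit of the assay and not a number (the limit of > 30 ug/mL in this assay, at which 1 of the 3 values shown sits). Compound 1 `C=C1C(=O)O[C@@H]2[C@@H]1C[C@H](OC(C)=O)[C@](C)(O)CC/C=C(\C)CC/C=C(\C)[C@@H]2OC(C)=O` differs from compound 2 by acetoxy in place of hydrogen on a saturated ring carbon; in this assay compound 1 gives 12.1 ug/mL, and the step is an at least 2.4-fold lower number from compound 2 to compound 1 (0.39 log units; beyond the scatter). Compound 3 `C=C1C(=O)O[C@H]2C/C(C)=C/CC/C(C)=C/CC[C@@](C)(O)[C@@H](O)C[C@H]12` differs from compound 2 by hydrogen in place of acetyl on an oxygen on a saturated carbon; in this assay compound 3 gives 12.5 ug/mL, a step of an at least 2.4-fold lower number from compound 2 to compound 3 (0.38 log units; beyond the scatter). The values of compound 1 and compound 3 lie within the usual scatter of each other.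

Compound 4 `C=C1C(=O)O[C@@H]2[C@@H]1C[C@H](O)[C@](C)(O)CC/C=C(\C)CC/C=C(\C)[C@@H]2OC(C)=O` stands to compound 3 as compound 1 stands to compound 2: acetoxy in place of hydrogen on a saturated ring carbon. This is the same kind of change, not the same, since around its place compound 4 has the acetoxy group four ring bonds from the ring atom that bears a hydroxy group, whereas in compound 1 it sits four ring bonds from the ring atom that bears an acetoxy group. The expected step of a 1.6-fold lower number from compound 3 to compound 4 (0.19 log units; within the scatter) rests on the earlier step of an at least 2.4-fold lower number from compound 2 to compound 1 (0.39 log units; beyond the scatter), which began at a limit and so gives only a lower bound to its size. Compound 4 is therefore expected to give 8 ug/mL in this assay, estimated to fall between 3.5 ug/mL and 22 ug/mL.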

Compound 4, half-maximal inhibitory concentration: 11.9 ug/mL
For compound 4 the middle estimate is 1.5-fold (0.17 log units) below the measured one; measured number inside the range.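

In this assay, acetoxy in place of hydrogen on a saturated ring carbon gives a 1.1-fold lower number from compound 3 to compound 4 (0.02 log units; within the scatter), and set beside the earlier step, this does not fix how well the change carries from one core to the other: the same change on two cores in this assay, an at least 2.4-fold lower number (0.39 log units; beyond the scatter) from compound 2 to compound 1 and a 1.1-fold lower number (0.02 log units; within the scatter) from compound 3 to compound 4; the limit leaves it open whether they differ. Hydrogen in place of acetyl on an oxygen gives a 1.0-fold lower number from compound 1 to compound 4 (0.01 log units; within the scatter), and the comparison with its earlier step ends the same way: the same change on two cores in this assay, an at least 2.4-fold lower number (0.38 log units; beyond the scatter) from compound 2 to compound 3 and a 1.0-fold lower number (0.01 log units; within the scatter) from compound 1 to compound 4; the limit leaves it open whether they differ. The series thus shows that neither change, when it ends at compound 4, moves the number beyond the scatter, but it does not show whether either change acts alike or differently on the core of compound 2, whose entry is a limit.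

Going by these compounds, how far compound 2 truly lies from compound 1 and compound 3 stays open. Also open, on these data alone, is whether a longer acyl chain in place of the acetyl, or an amine in place of the acetoxy group, would move the number in this assay.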